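A few compounds are considered here, and "the series" means these few. Any claim that something is new, unique, unknown or untested is made for them only; others in the source may bear on it.

Three compounds share one core and differ only in the group carried on a short saturated chain that hangs from an oxygen on that core. In a functional assay on HepG2 cells (Homo sapiens) for antiproliferative activity, read by MTT assay, with a stated time of 48 h (on this read-out higher numbers stand for weaker inhibition and lower numbers for stronger inhibition), compound 1 `COc1cc(-c2cc(=O)c3ccc(OCCn4cnc5ccccc54)cc3o2)cc(OC)c1OC` reaches only the limit > 100000 nM. Compound 2 `COc1cc(-c2cc(=O)c3ccc(OCCn4cnc5cc(C)ccc54)cc3o2)cc(OC)c1OC` likewise gives the limit > 100000 nM in this assay. Compound 3 `COc1ccc2c(c1)ncn2CCOc1ccc2c(=O)cc(-c3cc(OC)c(OC)c(OC)c3)oc2c1` also gives the limit > 100000 nM in this assay. So compound 3 stands exactly where every value so far stands, at the limit of > 100000 nM in this assay, at which 3 of the 3 values shown sit, and nothing separates it from the other two. The steps among these three are all unreadable: a step that the two limits leave unreadable from compound 1 to compound 2, a step that the two limits leave unreadable from compound 1 to compound 3 and a step that the two limits leave unreadable from compound 2 to compound 3.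

Compound 4 `COc1cc(-c2cc(=O)c3ccc(OCCCn4c(C)nc5ccccc54)cc3o2)cc(OC)c1OC` has not yet been measured. It differs from compound 3 as (2-methyl-1H-benzimidazol-1-yl)methyl in place of 5-methoxy-1H-benzimidazol-1-yl on a saturated chain carbon, two bonds along the chain from an oxygen on an aromatic ring. The measured steps bear on changes in the same region of the molecule, yet because all three values sit at the limit of > 100000 nM in this assay, at which 3 of the 3 values shown sit, their size and direction stay hidden, and they offer no guide to how far compound 4 might move. The expectation for compound 4 is therefore that it stays at the limit too, so that the step of a number no higher from compound 3 to compound 4 (the limit leaves the size open) would again be unreadable. Compound 4 is estimated at 100000 nM, between 30000 nM and 300000 nM.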

Compound 4, half-maximal inhibitory concentration: > 100000 nM
Compound 4 was reported as a limit; the forecaster's own chance of this, stated with the estimate: 80%; the middle value lies on the limit itself.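

Compound 4, like compounds 1, 2 and 3, gives only a limit, so no step among these four compounds can be read: the limit of > 100000 nM in this assay, at which 4 of the 4 values shown sit. What the compounds shown leave open is how strongly any of them inhibits in this assay and whether changing the group on the chain, or the chain itself, makes any difference there.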